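Swapping Ethyl for Oxiranyl at the Benzylic Position

This account rests on a few compounds, and the source may have more. Where it says the series, first, only, none or still open, it means among the compounds named here.

Compound 1 `CC(=O)c1cc(C)c(OCCCCC#N)cc1O`: 79%
Compound 2 `CCCc1cc(C(C)=O)c(O)cc1OCCCCC#N`: 84%

Both compounds were tested in an assay on isolated protein for inhibition of leukotriene B4 receptor 1 (Homo sapiens), tested at 10 uM; a higher number here means more inhibition at the concentration tested (going by the name of the read-out), a lower number less inhibition. Compound 2 gives the higher of the two figures, with compound 1 nearest to it, but the step of a number 5 percentage points higher from compound 1 to compound 2 (within the scatter) lies within the scatter, so on these numbers the two compounds cannot be told apart.

Compound 3 `CC(=O)c1cc(CC2CO2)c(OCCCCC#N)cc1O` has not yet been measured. It differs from compound 2 in one place: oxiran-2-yl in place of ethyl on a saturated chain carbon bound to an aromatic carbon. Among the compounds with values here, the only measured step that touches this same place is the one from compound 1 to compound 2, where hydrogen became ethyl and a number 5 percentage points higher from compound 1 to compound 2 (within the scatter) stayed within the scatter. Nothing measured here speaks to an oxirane ring at that position. Within the data shown here, because the one relevant step a number 5 percentage points higher from compound 1 to compound 2 (within the scatter) was small, the expectation for compound 3 is a step of a number 6 percentage points lower from compound 2 to compound 3 (within the scatter) of no clear size in either direction, most likely within the scatter. Compound 3 is therefore estimated at 78%, with a range from 55% to 92%.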

Compound 3, a percentage reported as inhibition, at one concentration (the size of the read-out at that concentration, not a potency): 62%
Estimate against measurement, compound 3: 16 percentage points above; low and high end bracket the measured number.
By their numbers in this assay, from the lowest: compound 3; then compounds 1 and 2 (each within the scatter of the next).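

In this assay, the earlier pair showed only that hydrogen and ethyl on this saturated chain carbon bound to an aromatic carbon could not be told apart, which left open whether the group at this place matters at all. Within the data shown here, the oxiran-2-yl group gives the first steps here that lie beyond the scatter, with a number 22 percentage points lower from compound 2 to compound 3 (beyond the scatter) and a number 17 percentage points lower from compound 1 to compound 3 (beyond the scatter), so the group at this place can change the read-out, although both steps are modest and rest on a single tested concentration, which says nothing about potency. The change brings in a three-membered ring and an oxygen together, and nothing available here bears on why the number falls.

The compounds shown do not separate the ring from its oxygen: a cyclopropylmethyl group would keep the three-membered ring without the oxygen, while a 2-methoxyethyl group would keep the oxygen without the ring. They also leave open how an amine or a carboxylic acid at this place would compare, and whether a longer plain carbon chain would still match compound 2.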